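Chloro added to the sulfonyl ring of compound 1

The compounds below may be only part of what the source reports. "The series", "measured", "known", "first", "only" and "open" are said of these compounds alone.

Measured in a functional assay on K562 cells (Homo sapiens) for inhibition, read by trypan blue exclusion, with a stated time of 72 h; on this read-out lower numbers stand for stronger inhibition and higher numbers for weaker inhibition:
compound 1 `Cn1c(=O)c(S(=O)(=O)c2ccc(Cl)cc2)cc2cnc(Nc3ccc4[nH]ccc4c3)nc21`: 100 nM
compound 2 `Cn1c(=O)c(S(=O)(=O)c2ccc(Cl)cc2)cc2cnc(Nc3cnc4ccccc4c3)nc21`: 15000 nM
compound 3 `Cn1c(=O)c(S(=O)(=O)c2ccc(Cl)cc2)cc2cnc(Nc3cnc4[nH]ccc4c3)nc21`: 5000 nM

Compound 1 gives the lowest number of the three. The steps from it are large: a 150-fold higher number from compound 1 to compound 2 (2.18 log units; beyond the scatter) and a 50-fold higher number from compound 1 to compound 3 (1.70 log units; beyond the scatter), with a 3.0-fold lower number from compound 2 to compound 3 (0.48 log units; beyond the scatter) between the other two. All three steps change only the group on the nitrogen on the aromatic ring.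

Compound 4 `Cn1c(=O)c(S(=O)(=O)c2ccc(Cl)cc2Cl)cc2cnc(Nc3ccc4[nH]ccc4c3)nc21` differs from compound 1 elsewhere: chloro in place of hydrogen on an aromatic carbon, so that the 4-chlorophenyl becomes 2,4-dichlorophenyl. Going by the values given here, no measured step touches this part of the shared core, so nothing here tells how the number should move. The expected step is no change at the digits printed from compound 1 to compound 4 (within the scatter), not beyond the scatter. Compound 4 is therefore estimated at 100 nM, with a range from 30 nM to 400 nM.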

Compound 4, half-maximal inhibitory concentration: 1000 nM
For compound 4 the middle estimate is 10-fold (1.00 log units) below the measured one; measured number outside the range, above it.
By their numbers in this assay, from the lowest: compound 1; then compound 4; then compound 3; then compound 2.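

In this assay, the change from (4-chlorophenyl)sulfonyl to (2,4-dichlorophenyl)sulfonyl gives a 10-fold higher number from compound 1 to compound 4 (1.00 log units; beyond the scatter). Going by these compounds alone, this is the first sign that the number responds to a change outside the group on the nitrogen, here from a single added chloro on the carbon-only aromatic ring. Nothing available explains this rise.

Going by these compounds, whether fluoro, methyl or methoxy at this same place would raise the number as well remains open. So does whether the existing chloro of the 4-chlorophenyl matters, which an unsubstituted phenyl would test.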